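A few compounds are considered here, and "the series" means these few. Any claim that something is new, unique, unknown or untested is made for them only; others in the source may bear on it.

Measured so far in an ADME assay on MT4 cells (Homo sapiens) for cytotoxicity, read by MTT assay, with a stated time of 4 days; on this read-out higher numbers stand for lower toxicity in this test and lower numbers for higher toxicity in this test:
compound 1 `Cc1ccc(NC(=O)CS(=O)(=O)c2nccc(Oc3c(C)cc(C#N)cc3C)n2)cc1` gives 7490 nM
compound 2 `Cc1cc(C#N)cc(C)c1Oc1ccnc(S(=O)(=O)CC(=O)Nc2ccccc2F)n1` gives 28400 nM
compound 3 `Cc1cc(C#N)cc(C)c1Oc1ccnc(S(=O)(=O)CC(=O)Nc2cccc(F)c2)n1` gives 25900 nM

On these numbers, compound 3 stands level with compound 2 (a 1.1-fold lower number from compound 2 to compound 3 (0.04 log units; within the scatter)) and clear of compound 1 (a 3.5-fold higher number from compound 1 to compound 3 (0.54 log units; beyond the scatter)). The next compound to be read, compound 4 `Cc1cc(C#N)cc(C)c1Oc1ccnc(S(=O)(=O)CC(=O)Nc2ccc(F)cc2)n1`, carries 4-fluorophenyl in place of 3-fluorophenyl on an amide-type nitrogen, with the same atoms joined differently.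

Going by the values given here, the nearest precedent is the exchange between the two measured fluorophenyl groups, and that step stayed within the scatter. The steps from 4-methylphenyl to these groups were modest but beyond the scatter (a 3.8-fold higher number from compound 1 to compound 2 (0.58 log units; beyond the scatter)) and (a 3.5-fold higher number from compound 1 to compound 3 (0.54 log units; beyond the scatter)). Among the compounds with values here, no measured compound yet carries 4-fluorophenyl, so these steps bear on compound 4 only indirectly. Within the data shown here, the one caution is compound 1, the only measured compound with a group named at the 4 place, which gives the lowest number here (7490 nM). That leaves some room on the low side.

The expected change is none beyond the scatter (a 1.2-fold lower number from compound 3 to compound 4 (0.07 log units; within the scatter)). For compound 4 the estimate in this assay is about 22000 nM (expected range 10000 nM to 45000 nM).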

Compound 4, half-maximal cytotoxic concentration: 26100 nM
Estimate against measurement, compound 4: 1.2-fold (0.07 log units) below; the measured number falls inside the stated range.
By their numbers in this assay, from the lowest: compound 1; then compounds 3, 4 and 2 (each within the scatter of the next).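

In this assay, the series now holds the fluoro group in all three named arrangements on the amide-type nitrogen, and the last of them adds nothing to the earlier exchange: a 1.0-fold higher number from compound 3 to compound 4 (0.00 log units; within the scatter), and a 1.1-fold lower number from compound 2 to compound 4 (0.04 log units; within the scatter). Among 2-fluorophenyl, 3-fluorophenyl and 4-fluorophenyl, the arrangement of the fluoro group therefore makes no difference to this read-out that can be told from the scatter. The series also gains its first direct exchange between 4-methylphenyl and 4-fluorophenyl, a 3.5-fold higher number from compound 1 to compound 4 (0.54 log units; beyond the scatter), which shows that the low number of compound 1 does not follow from having a group named at the 4 place, and nothing measured here accounts for the difference.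

The compounds shown leave open whether the lower number of compound 1 is specific to the methyl group or would recur with other groups at the 4 place, such as chloro, methoxy or ethyl. They also leave open where unsubstituted phenyl would fall, and whether a carboxylic acid or an amine on the same ring would move the number beyond the range of the fluorophenyl compounds.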